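A few compounds are considered here, and "the series" means these few. Any claim that something is new, unique, unknown or untested is made for them only; others in the source may bear on it.

In an ADME assay on microsomes from liver (Mus musculus) for metabolic stability, read by LC-MS, using NADPH, with a stated time of 30 min, tested at 0.5 uM (on this read-out higher numbers stand for fast clearance and lower numbers for slow clearance), compound 3, `c1ccc2c(CN3CCC4(CC3)OCCc3sccc34)c[nH]c2c1`, gives 7 mL/min/g, the lowest of the two numbers recorded here. Compound 1, `c1ccc(Oc2ccc(CN3CCC4(CC3)OCCc3sccc34)cc2)cc1`, gives 28.8 mL/min/g in this assay, a higher number that lies beyond the usual scatter. Compound 2, `Cn1cc(CN2CCC3(CC2)OCCc2sccc23)c2ccccc21`, is reported in this assay only as a limit of the assay, > 30 mL/min/g, rather than as a number. For the measured compounds named here, the one step measured between close neighbours, an at least 4.2-fold lower number from compound 2 to compound 3 (0.63 log units; beyond the scatter), is therefore read against the limit of > 30 mL/min/g in this assay, at which 1 of the 3 values shown sits, and is known only as a floor on its size. Compound 4, `Clc1ccc2c(CN3CCC4(CC3)OCCc3sccc34)c[nH]c2c1`, differs from compound 3 in one place: chloro in place of hydrogen on an aromatic carbon. Going by the values given here, none of the measured steps touches this kind of change; the only step recorded concerns hydrogen in place of methyl on an aromatic nitrogen, and it offers no guide to chloro in place of hydrogen on an aromatic carbon. Among the compounds with values here, with no comparable step to draw on, the expected change in this assay is none beyond the scatter, that is no change at the digits printed from compound 3 to compound 4 (within the scatter). Compound 4 is accordingly estimated to give 7 mL/min/g in this assay, with a range from 3 mL/min/g to 16 mL/min/g.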

Compound 4, intrinsic clearance in a liver preparation (reported as CLH), per the amount of preparation that the assay uses: 10.3 mL/min/g
Compound 4: the middle estimate sits 1.5-fold (0.17 log units) below what was measured; measured number inside the range.
By their numbers in this assay, from the lowest: compounds 3 and 4 (each within the scatter of the next); then compound 1. At a limit, above all of these: compound 2.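

Putting chloro in place of hydrogen on this aromatic carbon of the six-membered ring gives a 1.5-fold higher number from compound 3 to compound 4 (0.17 log units; within the scatter) in this assay, so this position takes a single chlorine atom with no change that can be told apart from repeat measurements. For the compounds shown here, until now the only step read lay on the aromatic nitrogen, and this is the first reading of a change on the carbon part of that fused system. Nothing at hand explains why the number stays within the scatter for this change.

One chloro group at one position cannot speak for other groups there, such as fluoro, methoxy or an amine, or for chloro on the other carbons of that ring. On these data alone, whether those changes would also leave the number within the scatter remains open.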